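The compounds below may be only part of what the source reports. "The series", "measured", "known", "first", "only" and "open" are said of these compounds alone.

Compound 1 (`FC(F)(F)c1ccc(NCCNc2ncc(-c3ncc[nH]3)c(-c3ccc(Cl)cc3Cl)n2)nc1`) was tested in an ADME assay on microsomes from liver (Rattus norvegicus) for metabolic stability; a higher number here means that the compound lasts longer, a lower number that the compound disappears faster. For compound 1 the read-out is a limit of the assay, > 0.5 h, and not a number. Compound 2 (`Nc1nc(NCCNc2ncc(-c3ncc[nH]3)c(-c3cc(F)ccc3Cl)n2)ccc1[N+](=O)[O-]`) was tested in this assay as well. For compound 2 the read-out is likewise a limit of the assay, > 0.5 h, so only a range is known for it. Compound 2 thus stands where every value shown stands: the limit of > 0.5 h in this assay, at which 2 of the 2 values shown sit. Compound 3 (`Nc1nc(NCCNc2ncc(-c3ncc[nH]3)c(-c3ccc(Cl)cc3Br)n2)ccc1[N+](=O)[O-]`) has not yet been measured in this assay. It differs from compound 2 in one place: 2-bromo-4-chlorophenyl in place of 2-chloro-5-fluorophenyl on an aromatic carbon. No measured step links any two of these compounds, so there is nothing to gauge this change against. The expected step in this assay is a step that the limit leaves unreadable from compound 2 to compound 3, which is no more than the usual scatter. Compound 3 is therefore expected to give 0.8 h, in a range from 0.3 h to 2 h.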

Compound 3, half-life: > 0.5 h
Compound 3 gave a limit, no number; the forecaster's own chance of this, stated with the estimate: 65%; the middle value is on the limit's open side.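

In this assay, within the data shown here, compound 3 gives > 0.5 h, which is a limit and not a number, so no step from compound 2 can be read. The actual half-lives of compound 1, compound 2 and compound 3 stay open, as does any effect of the swapped group: the limit of > 0.5 h in this assay, at which 3 of the 3 values shown sit.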